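The source may hold more compounds than are shown below. What is called first, only, known or untested is meant among the compounds shown, and "the series" means these compounds.

Compound 1 `c1ccc(Cn2cnc3c(-c4ccco4)nccc32)cc1` in an ADME assay on HepG2 cells (Homo sapiens) for cytotoxicity, read by trypan blue exclusion, with a stated time of 48 h, in the presence of a further agent that is not named here (a higher number here means that more compound is tolerated, a lower number that less compound is tolerated), gave > 25000 nM, which is a limit of the assay. Compound 2 `COc1ccc(NC(=O)COc2cc(C)nc3ccc(OC)cc23)c(OC)c1` gave > 131000 nM, also a limit of the assay. Compound 3 `COc1ccc2nc(C)cc(OCC(=O)Nc3cccc(Br)c3)c2c1` gave > 125000 nM, again a limit of the assay.

Compound 3 therefore stands nowhere that can be ranked: its result is only a limit, and the two other values shown are limits as well, as the limit of > 125000 nM in this assay, at which 1 of the 3 values shown sits, the limit of > 131000 nM in this assay, at which 1 of the 3 values shown sits, and the limit of > 25000 nM in this assay, at which 1 of the 3 values shown sits, record. Within the data shown here, none of the three compounds showed measurable cytotoxicity within the tested range, and no step between measured compounds is available.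

As far as these compounds go, compound 4 `C#CCNC(=O)COc1cc(C)nc2ccc(OC)cc12` is untested. It differs from compound 3 in one place (propargyl in place of 3-bromophenyl on an amide-type nitrogen), that is, propargyl in place of 3-bromophenyl on an amide-type nitrogen. Among the measured compounds shown here, with no measured step to lean on, the expectation for the step from compound 3 to compound 4 in this assay is one of no change beyond the scatter, and most likely another limit at the top of the tested range. The value of compound 4 in this assay is estimated at 125000 nM, with a range from 60000 nM to 250000 nM, with a number no higher from compound 3 to compound 4 (the limit leaves the size open) as the expected step.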

Compound 4, half-maximal cytotoxic concentration: > 176000 nM
Compound 4: no number, only a limit; the forecaster's own chance of this, stated with the estimate: 80%; middle value at least 1.4-fold (0.14 log units) away from the limit.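

In this assay compound 4 gives > 176000 nM, which is a limit of the assay. Among these compounds, compound 3 gives > 125000 nM, also a limit, so no step from compound 3 to compound 4 can be read. The compounds shown leave open whether propargyl in place of 3-bromophenyl on an amide-type nitrogen alters the half-maximal cytotoxic concentration at all.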